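The compounds below may be only part of what the source reports. "The series", "measured", "known", "first", "only" and "open" are said of these compounds alone.

Measured compounds:
compound 1 `N=C1/C(=N\Nc2ccc(S(N)(=O)=O)cc2)C(N)=NN1c1ccccc1C(=O)O` — 2730 nM in an assay on isolated protein for inhibition of Polyunsaturated fatty acid 5-lipoxygenase (Homo sapiens), read by colorimetric assay; a lower number here means a stronger inhibitor, a higher number a weaker inhibitor
compound 2 `N=C1/C(=N\Nc2ccc(S(N)(=O)=O)cc2)C(N)=NN1c1ccc(S(N)(=O)=O)cc1` — 2780 nM
compound 3 `CC1=NN(c2ccc(S(N)(=O)=O)cc2)C(=O)/C1=N/Nc1ccc(C(=O)O)cc1` — 530 nM

Of these three numbers, compound 3 gives the lowest; compound 1 and compound 2 both sit beyond the scatter above it, at about the same distance. Compound 4 `CC1=NN(c2ccc(S(N)(=O)=O)cc2)C(=O)/C1=N/Nc1ccc(S(N)(=O)=O)cc1` has not yet been measured. It arises from compound 3 by a single change: sulfamoyl in place of carboxy on an aromatic carbon. Going by the values given here, no step between measured compounds follows this exact change on this core. Compound 1 and compound 2, which carry carboxy and sulfamoyl on another position of a different core, show values that lie within the scatter of each other. On that basis the step from compound 3 to compound 4 is expected to be small, a 1.3-fold higher number from compound 3 to compound 4 (0.12 log units; within the scatter), likely within the scatter. Compound 4 is therefore estimated at 700 nM, with a range from 300 nM to 1800 nM.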

Compound 4, half-maximal inhibitory concentration: 570 nM
For compound 4 the middle estimate is 1.2-fold (0.09 log units) above the measured one; low and high end bracket the measured number.
By their numbers in this assay, from the lowest: compounds 3 and 4 (each within the scatter of the next); then compounds 1 and 2 (each within the scatter of the next).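

In this assay, going by these compounds alone, sulfamoyl in place of carboxy on this aromatic carbon, para to a large group, gives a 1.1-fold higher number from compound 3 to compound 4 (0.03 log units; within the scatter) on the shared core, the first direct reading of this change on that core. At this place the two groups therefore cannot be told apart in the assay. Nothing available here explains why they read alike. The compounds shown leave open whether an amine, a nitrile or a methyl ester on the same aromatic carbon would read alike too.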